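Ethyl for Cyclopropyl on the Piperazine of Compound 2

The source may report more compounds than this note shows. Statements on the series, on what has been measured and on what is new or still open speak of the compounds shown alone.

For the measured compounds named here, in a functional assay on CHO-K1 cells for antagonist activity at Urotensin-2 receptor (Rattus norvegicus), read by FLIPR and calcium flux, with a stated time of 1 h (a lower number here means a stronger inhibitor, a higher number a weaker inhibitor), compound 2 `COc1ccc([C@@H](CCCN(C)S(=O)(=O)c2cccs2)N2Cc3c(cccc3N3CCN(C4CC4)CC3)C2=O)cc1OC` gives 13 nM, the lowest of the two numbers measured so far. Its nearest neighbour is compound 1 `CCN1CCN(c2cccc3c2CN([C@H](CCCNC(=O)c2c(C)n[nH]c2C)c2ccc(OC)c(OC)c2)C3=O)CC1`, which in this assay gives 16 nM; the two values lie within the scatter, so neither can be set apart from the other. Compound 3 `CCN1CCN(c2cccc3c2CN([C@H](CCCN(C)S(=O)(=O)c2cccs2)c2ccc(OC)c(OC)c2)C3=O)CC1` keeps the side chain of compound 2 and alters only the ring substituent: ethyl in place of cyclopropyl on an amine nitrogen in a ring. Going by the values given here, no single-point step between measured compounds is available to calibrate this change, and compound 1 differs from compound 2 in two places at once, so it offers no direct guide. The change is small, and the step in this assay is expected to stay within the scatter, in no particular direction: a 1.2-fold higher number from compound 2 to compound 3 (0.06 log units; within the scatter). Compound 3 is accordingly expected to give 15 nM in this assay, with a range from 6 nM to 40 nM.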

Compound 3, half-maximal inhibitory concentration: 7 nM
Compound 3: the middle estimate sits 2.1-fold (0.33 log units) above what was measured, within the range that was stated.
By their numbers in this assay, from the lowest: compounds 3, 2 and 1 (each within the scatter of the next, the first and the last beyond it).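

In this assay, the exchange on this amine nitrogen can now be read directly, and the step (a 1.9-fold lower number from compound 2 to compound 3 (0.27 log units; within the scatter)) shows that the three-membered ring of cyclopropyl can give way to the open ethyl group without a change that stands clear of the scatter. With ethyl held in common, the chain can also be read on its own: methyl((thiophen-2-yl)sulfonyl)amino in place of ((3,5-dimethyl-1H-pyrazol-4-yl)carbonyl)amino gives a modest step (a 2.3-fold lower number from compound 1 to compound 3 (0.36 log units; beyond the scatter)). Nothing available accounts for either step.

From the compounds shown here alone, whether this piperazine nitrogen would accept a bare hydrogen, a methyl, an isopropyl or an acetyl in place of ethyl remains open. Going by these compounds, on the chain, it is also open whether the step would hold with a phenyl in place of the thiophene or with a hydrogen in place of the methyl on the sulfonyl-bearing nitrogen.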